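From 4-nitrophenyl to 2-nitrophenyl on a sulfonyl sulfur

The source may hold more compounds than are shown below. What is called first, only, known or untested is meant among the compounds shown, and "the series" means these compounds.

Values measured in a functional assay on HL-60 cells (Homo sapiens) for inhibition, read by CCK-8 assay, with a stated time of 48 h, tested at 20 uM (on this read-out lower numbers stand for less inhibition of growth and higher numbers for more inhibition of growth at the one concentration tested), are:
- compound 1 `Cc1ccc(S(=O)(=O)Oc2ccccc2/C=C(\C#N)C(=O)Nc2nnc(Cc3cccc4ccccc34)s2)cc1` gives 19%
- compound 2 `N#C/C(=C\c1ccccc1OS(=O)(=O)c1ccc([N+](=O)[O-])cc1)C(=O)Nc1nnc(Cc2cccc3ccccc23)s1` gives 18%

Compound 2 at 18% lies within the scatter of compound 1 at 19% on these numbers. Compound 3 `N#C/C(=C\c1ccccc1OS(=O)(=O)c1ccccc1[N+](=O)[O-])C(=O)Nc1nnc(Cc2cccc3ccccc23)s1` carries the change 2-nitrophenyl in place of 4-nitrophenyl on a sulfonyl sulfur in the sulfonyl part. For the measured compounds named here, the only measured step, a number 1 percentage points lower from compound 1 to compound 2 (within the scatter), is nitro in place of methyl on an aromatic carbon, and it does not test this change directly. The estimated step is a number 2 percentage points higher from compound 2 to compound 3 (within the scatter), so no step beyond the scatter is expected. For compound 3 the expected value is 20%, with an estimated range from 8% to 38% in this assay here.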

Compound 3, percent growth inhibition at one concentration: 23%
Compound 3: the middle estimate sits 3 percentage points below what was measured; low and high end bracket the measured number.
By their numbers in this assay, from the lowest: compounds 2, 1 and 3 (each within the scatter of the next).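

In this assay the change to 2-nitrophenyl in place of 4-nitrophenyl on a sulfonyl sulfur gives a number 5 percentage points higher from compound 2 to compound 3 (within the scatter) and 2-nitrophenyl in place of 4-methylphenyl there gives a number 4 percentage points higher from compound 1 to compound 3 (within the scatter) on the same read-out. The position of the nitro group on this ring is now tested directly, and neither step separates the compounds. No evidence is available to explain these readings.

Still open, going by these compounds, is how this assay would read with an amine or a carboxylic acid on this ring, or with a longer chain on the sulfonyl sulfur in place of the ring.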